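A Methoxy Group Enters the Cyclobutyl Ring of Compound 2

A few compounds are considered here, and "the series" means these few. Any claim that something is new, unique, unknown or untested is made for them only; others in the source may bear on it.

Compound 1 `CCn1c(-c2cnc(C)nc2)nc2c(O[C@H]3CCN(C(=O)C4CC4)C3)ncnc21` and compound 2 `CCn1c(-c2cnc(C)nc2)nc2c(N[C@H]3CCN(C(=O)C4CCC4)C3)ncnc21` share one core. In an ADME assay (Canis lupus familiaris, strain Beagle) for metabolic stability (on this read-out lower numbers stand for a shorter-lived compound and higher numbers for a longer-lived compound), compound 1 gives 1.3 h, and compound 2 gives 1.3 h. Compound 2 thus stands level with compound 1, the two values lying within the usual scatter. Compound 3 `CCn1c(-c2cnc(C)nc2)nc2c(N[C@H]3CCN(C(=O)[C@H]4C[C@@H](OC)C4)C3)ncnc21` differs from compound 2 in a single place: methoxy in place of hydrogen on a saturated ring carbon. Going by the values given here, no measured pair shows this change, so the data offer no step to lean on. The step from compound 2 to compound 3 is expected to be small, a 1.2-fold higher number from compound 2 to compound 3 (0.06 log units; within the scatter), and not beyond the scatter. Compound 3 is therefore estimated at 1.5 h, within a range of 0.7 h to 3 h.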

Compound 3, half-life: 4.3 h
For compound 3 the middle estimate is 2.9-fold (0.46 log units) below the measured one; measured number above the stated range.
By their numbers in this assay, from the lowest: compounds 1 and 2 (each within the scatter of the next); then compound 3.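

In this assay, the change from cyclobutyl to 3-methoxycyclobutyl gives a 3.3-fold higher number from compound 2 to compound 3 (0.52 log units; beyond the scatter) and so moves the half-life beyond the scatter. This shows that the saturated ring carbon, two ring bonds from the ring atom that bears a large group, is a place where a small group can change this read-out. Nothing measured here bears on the reason for the step.

As far as these compounds go, it remains open whether methoxy is special at this carbon or whether hydroxyl, fluorine or ethoxy would do the same. The opposite ring arrangement of the methoxy group also remains untested in the compounds shown.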